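This account rests on a few compounds, and the source may have more. Where it says the series, first, only, none or still open, it means among the compounds named here.

Compound 3, `O=C(Nc1c(C(O)(C(F)(F)F)C(F)(F)F)ccc2ccccc12)c1cccc([N+](=O)[O-])c1`, gives 99% in a functional assay (Sus scrofa) with sulfonylurea receptors; K-ATP channels (Homo sapiens) as the target; a lower number here means a smaller maximal response, a higher number a larger maximal response. Among the three numbers measured it stands second highest, but its steps to the others are small: the step of a number 1 percentage points lower from compound 2 to compound 3 (within the scatter) separates it from compound 2, `O=C(Nc1c(C(O)(C(F)(F)F)C(F)(F)F)ccc2ccccc12)C1CC1`, which gives 100% in this assay, and the step of a number 3 percentage points higher from compound 1 to compound 3 (within the scatter) separates it from compound 1, `CC(C)=CC(=O)Nc1c(C(O)(C(F)(F)F)C(F)(F)F)ccc2ccccc12`, which gives 96% in this assay.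

Compound 4, `O=C(Nc1c(C(O)(C(F)(F)F)C(F)(F)F)ccc2ccccc12)c1ccco1`, differs from compound 3 in one place: furan-2-yl in place of 3-nitrophenyl on a carbonyl carbon. Every step seen so far exchanges the group on that same carbonyl carbon, and none of them left the scatter: a number 4 percentage points higher from compound 1 to compound 2 (within the scatter), a number 3 percentage points higher from compound 1 to compound 3 (within the scatter) and a number 1 percentage points lower from compound 2 to compound 3 (within the scatter). All three measured compounds therefore sit close to the full response of the reference in this assay, whatever the acyl group was. On this basis the expected step is a number 1 percentage points lower from compound 3 to compound 4 (within the scatter), that is, no change beyond the scatter. Compound 4 is estimated to give 98% in this assay, with a range from 87% to 106%.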

Compound 4, largest response reached (reported as efficacy), in percent of the reference or control that the assay uses: 96%
The estimate for compound 4 lay 2 percentage points above the measured number; the range from low to high includes it.
By their numbers in this assay, from the lowest: compounds 1, 4, 3 and 2 (each within the scatter of the next).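

In this assay furan-2-yl, a five-membered aromatic ring with a hetero atom, extends the series on this carbonyl carbon: against 3-nitrophenyl the step is a number 3 percentage points lower from compound 3 to compound 4 (within the scatter) and against cyclopropyl it is a number 4 percentage points lower from compound 2 to compound 4 (within the scatter) and against 2-methylprop-1-en-1-yl it is no change at the digits printed from compound 1 to compound 4 (within the scatter) at this position. The response at this position thus stays within the scatter even with this five-membered ring, which has fewer heavy atoms than 3-nitrophenyl. Nothing available explains why these different groups give such similar responses.

From the compounds shown here alone, it remains open whether an amine, a carboxylic acid or a longer alkyl chain on this carbonyl carbon would leave the response equally unchanged. The compounds shown also leave open how changes elsewhere on the shared core would affect it.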